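Swapping an Aryl Urea for a Saturated Sulfoxide Ring

The compounds below may be only part of what the source reports. "The series", "measured", "known", "first", "only" and "open" are said of these compounds alone.

Of the compounds shown here, three sharing one core have been tested in a functional assay on Shh Light II cells (Mus musculus) for inhibition, read by a luciferase reporter; on this read-out lower numbers stand for stronger inhibition and higher numbers for weaker inhibition. Compound 2 `O=C(Nc1ccccc1C(F)(F)F)N1CCC(c2nc(-c3ccc4ccccc4n3)no2)CC1` gives 700 nM, the lowest number of the three. Compound 3 `C[C@H]1C[C@H](c2nc(-c3ccc4ccccc4n3)no2)CCN1C(=O)Nc1ccccc1Cl` gives 900 nM, which sits within the scatter of compound 2, while compound 1 `C[C@@H]1C[C@H](c2nc(-c3ccc4ccccc4n3)no2)CCN1C(=O)Nc1ccccc1Cl` gives 2400 nM, a number beyond the scatter above compound 2. Among the compounds with values here, the only measured step, a 2.7-fold lower number from compound 1 to compound 3 (0.43 log units; beyond the scatter), goes back to the fact that compounds 1 and 3 differ only in the configuration as drawn. Compound 4 `O=C(NC1CC[S+]([O-])CC1)N1CCC(c2nc(-c3ccc4ccccc4n3)no2)CC1` differs from compound 2 on the urea side: a group of 7 heavy atoms (5 carbon, 1 oxygen, 1 sulfur; one six-membered non-aromatic ring with 1 hetero atom) in place of a group of 10 heavy atoms (7 carbon, 3 fluorine; one six-membered aromatic ring of carbon only), on an amide-type nitrogen. Within the data shown here, no measured step touches this position, so the stereochemical step offers no guide to it. Without such a guide, compound 4 is expected to inhibit more weakly than compound 2, a step of a 4.3-fold higher number from compound 2 to compound 4 (0.63 log units; beyond the scatter), with wide uncertainty. The estimated value for compound 4 is 3000 nM, expected between 700 nM and 15000 nM.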

Compound 4, half-maximal inhibitory concentration: 850 nM
Compound 4: middle estimate off by 3.5-fold (0.55 log units), on the high side, and the stated range covers the measured number.
By their numbers in this assay, from the lowest: compounds 2, 4 and 3 (each within the scatter of the next); then compound 1.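

The step here is a 1.2-fold higher number from compound 2 to compound 4 (0.08 log units; within the scatter). In this pair, then, an aromatic ring of carbon only is not needed on this amide-type nitrogen for a number in this range, as a non-aromatic ring with one hetero atom and fewer heavy atoms reads alike. Nothing measured here explains why the two groups read alike.

Going by these compounds, how a plain cyclohexyl ring or an open butyl chain on this nitrogen would read remains open. So does whether the sulfur and its oxygen contribute at all to the reading of compound 4.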